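The source may report more compounds than this note shows. Statements on the series, on what has been measured and on what is new or still open speak of the compounds shown alone.

Measured so far in an assay (strain Wistar) for displacement of a labelled ligand from adenosine receptor A1 (Rattus norvegicus), read by scintillation counting; a higher number here means a weaker inhibitor, a lower number a stronger inhibitor:

compound 1 `O=C(Nc1nc(-c2ccccc2)nc2c1nnn2Cc1ccccc1)c1ccc([N+](=O)[O-])cc1` gives 24 nM
compound 2 `O=C(Nc1nc(-c2ccccc2)nc2c1nnn2Cc1ccccc1)c1cccc(C(F)(F)F)c1` gives 163 nM

Going by the values given here, compound 2 stands at the higher of the two numbers, and the one step between them, a 6.8-fold higher number from compound 1 to compound 2 (0.83 log units; beyond the scatter), shows that changing the aromatic group on the carbonyl carbon moves the number by a clear amount.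

Compound 3 `O=C(Nc1nc(-c2ccccc2)nc2c1nnn2Cc1ccccc1)c1ccccc1F` differs from compound 2 in just this place: 2-fluorophenyl in place of 3-(trifluoromethyl)phenyl on a carbonyl carbon. Among the compounds with values here, the only step that bears on it is a 6.8-fold higher number from compound 1 to compound 2 (0.83 log units; beyond the scatter), which tells that the group in this position matters, but it does not say how a 2-fluorophenyl will behave, as neither measured compound carries it. The 2-fluorophenyl is smaller than the 3-(trifluoromethyl)phenyl, and it lacks the nitro group that the aryl of compound 1 carries. With nothing more to go on, compound 3 is expected to land between the two measured numbers, so the estimated step is a 2.3-fold lower number from compound 2 to compound 3 (0.37 log units; beyond the scatter), towards a lower number than compound 2 but not reaching compound 1 with confidence.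

The estimate for compound 3 in this assay is therefore 70 nM, in the range from 20 nM to 250 nM.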

Compound 3, inhibition constant: 40 nM
Compound 3: the middle estimate sits 1.8-fold (0.24 log units) above what was measured, and the stated range covers the measured number.
By their numbers in this assay, from the lowest: compounds 1 and 3 (each within the scatter of the next); then compound 2.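

In this assay, putting 2-fluorophenyl in place of 3-(trifluoromethyl)phenyl on the carbonyl carbon gives a 4.1-fold lower number from compound 2 to compound 3 (0.61 log units; beyond the scatter), so the higher number seen earlier does not extend to every aryl group without a nitro group. Replacing 4-nitrophenyl with 2-fluorophenyl gives a 1.7-fold higher number from compound 1 to compound 3 (0.22 log units; within the scatter), so these two different groups cannot be told apart in this assay, and a nitro group is not required for a number in this range; among the three groups, only 3-(trifluoromethyl)phenyl stands apart. No measurement is available here to explain why the groups rank this way.

The 2-fluorophenyl and 3-(trifluoromethyl)phenyl groups differ both in what is attached to the ring and in the number in their names, so the compounds shown cannot separate those two changes. From the compounds shown here alone, it also remains open how a plain phenyl would compare, how a phenyl carrying an amine or a carboxylic acid would behave, and whether a longer carbon chain could replace the aromatic ring on the carbonyl carbon altogether.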